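This account rests on a few compounds, and the source may have more. Where it says the series, first, only, none or still open, it means among the compounds named here.

Measured compounds:
Compound 1 `CC(C)=CCC/C(C)=C/CC/C(C)=C/C[N+](C)(C)CCCCS(=O)(=O)[O-]` gives 15000 nM in an assay on isolated protein for inhibition of squalene synthase (Rattus norvegicus); a lower number here means a stronger inhibitor, a higher number a weaker inhibitor.
Compound 2 `C[N+](C)(CCCCCCc1ccccc1)CCCCS(=O)(=O)[O-]` gives 100000 nM in this assay.
Compound 3 `C[N+](C)(CCCCCCCCc1ccccc1)CCCCS(=O)(=O)[O-]` gives 8000 nM in this assay.

Compound 2 stands highest of the three numbers in this assay; compound 1 shows a lower value, and compound 3 the lowest. Among the measured compounds shown here, the only step measured from compound 2 is the one to compound 3, a 13-fold lower number from compound 2 to compound 3 (1.10 log units; beyond the scatter), a large move in the direction of stronger inhibition when the aromatic end of the chain is pushed further out.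

Compound 4 `C[N+](C)(CCCCCCc1ccc(-c2ccccc2)cc1)CCCCS(=O)(=O)[O-]` differs from compound 2 by phenyl in place of hydrogen on an aromatic carbon. For the measured compounds named here, as in the step to compound 3, the change adds carbon at the far end of the molecule away from the charged nitrogen, so the step from compound 2 to compound 3 is the one measured step that bears on it. A step of the same direction is expected for compound 4 in this assay, though its size is uncertain with one step as guide; the estimate is an 8.3-fold lower number from compound 2 to compound 4 (0.92 log units; beyond the scatter). Compound 4 is therefore expected at 12000 nM, within 3000 nM to 50000 nM.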

Compound 4, half-maximal inhibitory concentration: 60000 nM
For compound 4 the middle estimate is 5.0-fold (0.70 log units) below the measured one; measured number outside the range, above it.
By their numbers in this assay, from the lowest: compounds 3 and 1 (each within the scatter of the next); then compounds 4 and 2 (each within the scatter of the next).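

In this assay, phenyl in place of hydrogen on an aromatic carbon, para to a large group, gives a 1.7-fold lower number from compound 2 to compound 4 (0.22 log units; within the scatter) and so leaves compound 4 not separable from compound 2 at this position. The phenethyl change gives a 13-fold lower number from compound 2 to compound 3 (1.10 log units; beyond the scatter) while the phenyl change on the ring does not, so among these compounds added carbon at the far end of the molecule does not by itself go with stronger inhibition. No measurement at hand accounts for this difference between the two changes.

Going by these compounds, whether a smaller group such as methoxy or chlorine on the same aromatic carbon would behave like phenyl remains open. Also open, on these data alone, is whether phenyl on the ring of compound 3, with its longer chain, would give a step beyond the scatter.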